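Estimating a diethylaminopropyl amide against glutathione S-transferase P

A few compounds are considered here, and "the series" means these few. Any claim that something is new, unique, unknown or untested is made for them only; others in the source may bear on it.

Compound 1 `O=C(CCC(=O)OCCCCCCSc1ccc([N+](=O)[O-])c2nonc12)Nc1ccc(Br)cc1`: in an assay on isolated protein for inhibition of glutathione S-transferase P (Homo sapiens), with a stated time of 10 min (a lower number here means a stronger inhibitor, a higher number a weaker inhibitor), compound 1 gives 5090 nM.
Compound 2 `O=C(CCC(=O)OCCCCCCSc1ccc([N+](=O)[O-])c2nonc12)Nc1ccc(C(F)(F)F)cc1`: in this assay compound 2 gives 5050 nM.

Compound 2 stands lowest of the two numbers, but compound 1 lies within the scatter, so the two cannot be told apart. Among the measured compounds shown here, the one measured step, a 1.0-fold lower number from compound 1 to compound 2 (0.00 log units; within the scatter), exchanges one group for another on an aromatic carbon and changes nothing beyond the scatter. Compound 3 `CCN(CC)CCCNC(=O)CCC(=O)OCCCCCCSc1ccc([N+](=O)[O-])c2nonc12` differs from compound 2 by 3-(diethylamino)propyl in place of 4-(trifluoromethyl)phenyl on an amide-type nitrogen. For the measured compounds named here, no measured step exchanges the aromatic group for a chain, so there is no direct guide. The change expected in this assay is therefore a 1.2-fold higher number from compound 2 to compound 3 (0.07 log units; within the scatter), with wide uncertainty. Compound 3 is estimated at 6000 nM, between 1500 nM and 24000 nM.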

Compound 3, half-maximal inhibitory concentration: 9550 nM
For compound 3 the middle estimate is 1.6-fold (0.20 log units) below the measured one, within the range that was stated.
By their numbers in this assay, from the lowest: compounds 2, 1 and 3 (each within the scatter of the next).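

In this assay, the position on the amide-type nitrogen has now taken a change of a different kind, not just a swap on the aromatic ring. Replacing the aromatic group with 3-(diethylamino)propyl, which has no ring, gives a 1.9-fold higher number from compound 2 to compound 3 (0.28 log units; within the scatter) and a 1.9-fold higher number from compound 1 to compound 3 (0.27 log units; within the scatter), so the ring is not shown to matter here. Nothing available explains this result.

Still open, going by these compounds, is whether a plain phenyl, a shorter chain or a carboxylic acid on this nitrogen would read differently. On these data alone, it is also open whether any group here can move the number beyond the scatter.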